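Furan-2-yl for phenyl on the amide of the octyl series

The source may hold more compounds than are shown below. What is called first, only, known or untested is meant among the compounds shown, and "the series" means these compounds.

Two amides of the same threonine-derived core have been measured for cytotoxicity. Compound 1 `CCCCCCCCCCCCCCCCCCNC(=O)[C@@H](N)[C@@H](C)O` carries an octadecyl amide and a free amine; in a functional assay on HepG2 cells (Homo sapiens) for cytotoxicity, read by MTT assay, with a stated time of 48 h (on this read-out higher numbers stand for weaker inhibition and lower numbers for stronger inhibition), compound 1 gives 44500 nM. Compound 2 `CCCCCCCCNC(=O)[C@@H](NC(=O)c1ccccc1)[C@@H](C)O` carries an octyl amide and a benzoyl group on the nitrogen; in this assay compound 2 gives 136000 nM, the higher of the two numbers, and the two compounds differ in more than one place, so the gap is read only as what the two values show.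

Compound 3 `CCCCCCCCNC(=O)[C@@H](NC(=O)c1ccco1)[C@@H](C)O` keeps the whole of compound 2 except for one change: furan-2-yl in place of phenyl on a carbonyl carbon. With no measured step of this kind in the series, nothing points to a shift beyond the scatter in either direction. Compound 3 is therefore expected to sit close to compound 2, with the estimated step of a 1.0-fold lower number from compound 2 to compound 3 (0.02 log units; within the scatter). The estimate for compound 3 in this assay is 130000 nM, within a range from 60000 nM to 300000 nM.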

Compound 3, half-maximal inhibitory concentration: 192000 nM
Estimate against measurement, compound 3: 1.5-fold (0.17 log units) below; the range from low to high includes it.
By their numbers in this assay, from the lowest: compound 1; then compounds 2 and 3 (each within the scatter of the next).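

In this assay the change gives a 1.4-fold higher number from compound 2 to compound 3 (0.15 log units; within the scatter) and so, on this carbonyl carbon in the octyl series, furan-2-yl and phenyl cannot be told apart. The swap from benzoyl to (furan-2-yl)carbonyl replaces a six-membered carbon ring with a five-membered ring holding one hetero atom and adds one hydrogen-bond acceptor, yet the read-out stays within the scatter. Nothing available accounts for this outcome.

Still open, from the compounds shown here alone, is whether a saturated ring such as cyclohexyl, or a pyridin-3-yl ring with its ring nitrogen, on this carbonyl carbon would move the read-out beyond the scatter. Also open, going by these compounds, is whether furan-2-yl and phenyl would remain indistinguishable with a longer chain, such as octadecyl, on the other amide.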